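Anilide series at the dopamine D4 receptor: methylsulfanyl for dimethyl

The compounds below may be only part of what the source reports. "The series", "measured", "known", "first", "only" and "open" are said of these compounds alone.

Among the measured compounds shown here, in a functional assay on HEK293 cells for agonist activity at D(4) dopamine receptor (Homo sapiens), read by FLIPR (a higher number here means a larger maximal response, a lower number a smaller maximal response), compound 2 `Cc1cc(C)cc(NC(=O)CN2CCC(c3cccc[n+]3[O-])CC2)c1` gives 76%, the top number among the three measured members. Compound 1 `Cc1cccc(C(=O)NCN2CCC(c3nccs3)CC2)c1` gives 71% in this assay, which cannot be told apart from compound 2 within the usual scatter. Compound 3 `C=Cc1cccc(C(=O)NCN2CCC(c3cccc[n+]3[O-])CC2)c1` gives 63% in this assay, and this gap to compound 2 lies beyond the scatter.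

Compound 4 `CSc1cccc(NC(=O)CN2CCC(c3cccc[n+]3[O-])CC2)c1` differs from compound 2 in one place: 3-(methylsulfanyl)phenyl in place of 3,5-dimethylphenyl on an amide-type nitrogen. For the measured compounds named here, no measured pair carries this change, so nothing shows how the maximal response moves with it. The step of a number 6 percentage points lower from compound 2 to compound 4 (within the scatter) is expected to stay within the scatter, with no firm direction. Compound 4 is expected to give 70%, between 55% and 85%.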

Compound 4, largest response reached (reported as efficacy), in percent of the reference or control that the assay uses: 56%
Beside the measured number, compound 4's estimate is 14 percentage points above it; measured number inside the range.
By their numbers in this assay, from the lowest: compounds 4, 3, 1 and 2 (each within the scatter of the next, the first and the last beyond it).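

In this assay, among the compounds shown here, the change from 3,5-dimethylphenyl to 3-(methylsulfanyl)phenyl on the amide-type nitrogen gives the only one-place step, a number 20 percentage points lower from compound 2 to compound 4 (beyond the scatter) and so shows that the maximal response depends on the group at this place. The two groups have the same heavy-atom count, so that count alone does not fix the response in this pair. Nothing available explains the drop.

Open, from the compounds shown here alone, is whether the sulfur-bearing group or the missing second methyl drives the step. A 3-methylphenyl or 3-methoxyphenyl group on the same nitrogen would separate the two.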